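A Single Aromatic Swap and Its Expected Effect

The source may hold more compounds than are shown below. What is called first, only, known or untested is meant among the compounds shown, and "the series" means these compounds.

Of the compounds shown here, two have been measured in an assay on BaF3 cells with thrombopoietin receptor (Homo sapiens) as the target, read by a luciferase reporter; on this read-out higher numbers stand for larger maximal responses and lower numbers for smaller maximal responses. Compound 1 `O=S(=O)(O)c1cc(O)c(/N=C/c2c(O)ccc3ccccc23)c2ccccc12` reaches only a limit in this assay, < 5%, which is the limit of < 5% in this assay, at which 1 of the 2 values shown sits, rather than a number. Compound 2 `Cc1[nH]n(-c2cccc(C(F)(F)F)c2)c(=O)c1/N=N/c1c(O)cc(S(=O)(=O)O)c2ccccc12` gives 62% in this assay, the only plain number shown, so its standing rests on itself alone. Compound 3 `Cc1[nH]n(-c2ccc(C(C)(C)C)cc2)c(=O)c1/N=N/c1c(O)cc(S(=O)(=O)O)c2ccccc12` has not yet been measured. It differs from compound 2 in one place: 4-(tert-butyl)phenyl in place of 3-(trifluoromethyl)phenyl on an aromatic nitrogen. Going by the values given here, no measured step between compounds that differ in one place is available, so this change has no precedent here, and a moderate shift in either direction, or none beyond the usual scatter, is plausible. The expectation leans towards a small loss, and the step of a number 12 percentage points lower from compound 2 to compound 3 (beyond the scatter) is estimated on that basis. Compound 3 is expected to give 50% in this assay, with a likely range from 20% to 80%.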

Compound 3, largest response reached (reported as efficacy), in percent of the reference or control that the assay uses: 86%
Estimate against measurement, compound 3: 36 percentage points below; measured number outside the range, above it.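

Going by these compounds alone, exchanging 3-(trifluoromethyl)phenyl for 4-(tert-butyl)phenyl on the aromatic nitrogen gives a number 24 percentage points higher from compound 2 to compound 3 (beyond the scatter) in this assay, the first one-place change that can be read. The two groups match in everything counted, each with 10 heavy atoms, one six-membered aromatic ring of carbon only and no hydrogen-bond donors or acceptors, yet the maximal response still moves, so the group on this nitrogen matters beyond those counts. Nothing measured here explains why this change raises the response.

The two group names differ both in the substituent and in its number on the phenyl ring, so this single step cannot show which of the two drives the rise. On these data alone, how a phenyl ring carrying an amine or a carboxylic acid would behave on this nitrogen remains open.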